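Fluoro for trifluoromethoxy in a series at the limit

A few compounds are considered here, and "the series" means these few. Any claim that something is new, unique, unknown or untested is made for them only; others in the source may bear on it.

Values, all limits, from a functional assay on SEM cells (Homo sapiens) for cytotoxicity, with a stated time of 72 h; on this read-out higher numbers stand for an effect only at larger amounts of compound and lower numbers for an effect already at smaller amounts
- compound 1 `C=C[C@@](C)(/C=C/c1ccc(OS(=O)(=O)C(F)(F)F)cc1)CCC=C(C)C` gives > 36600 nM
- compound 2 `C=C[C@@](C)(/C=C/c1ccc(Nc2ccc(OC)cc2)cc1)CCC=C(C)C` gives > 36600 nM
- compound 3 `C=C[C@@](C)(/C=C/c1ccc(Nc2ccc(OC(F)(F)F)cc2)cc1)CCC=C(C)C` gives > 36600 nM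

Compound 3 sits at a limit (> 36600 nM) and not at a number. The other two compounds share this position (the limit of > 36600 nM in this assay, at which 3 of the 3 values shown sit). Compound 4 `C=C[C@@](C)(/C=C/c1ccc(Nc2ccc(F)cc2)cc1)CCC=C(C)C` carries fluoro in place of trifluoromethoxy on an aromatic carbon, para to a large group (fluoro in place of trifluoromethoxy on an aromatic carbon). For the measured compounds named here, two measured steps bear on this change (a step that the two limits leave unreadable from compound 1 to compound 2; a step that the two limits leave unreadable from compound 2 to compound 3). Neither has a readable size, so no clear step is expected in this assay and no direction can be drawn from them. The expected step is small (a step that the limit leaves unreadable from compound 3 to compound 4). The estimated value for compound 4 is 40000 nM (expected range 15000 nM to 80000 nM).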

Compound 4, half-maximal effective concentration: > 36600 nM
Compound 4: only a limit was reported; the forecaster's own chance of this, stated with the estimate: 80%; the middle value does not contradict the limit.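

Compound 4 gives only a limit, > 36600 nM, so no step from compound 1, compound 2 or compound 3 to compound 4 can be read: the limit of > 36600 nM in this assay, at which 4 of the 4 values shown sit.

The compounds shown leave open whether any group at this place gives a readable value.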